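Halogen swap on the fused ring: chloro to bromo

This account rests on a few compounds, and the source may have more. Where it says the series, first, only, none or still open, it means among the compounds named here.

Measured so far:
compound 1, `O=C1C(=O)N(CCCCCn2cc(COc3cc(=O)oc4ccccc34)nn2)c2ccccc21`, 62%
compound 2, `O=C1C(=O)N(CCCCn2cc(COc3cc(=O)oc4ccccc34)nn2)c2ccc(Cl)cc21`, 60%

Two compounds of this series have numbers in a functional assay on COLO 205 cells (Homo sapiens) for inhibition, read by sulforhodamine B assay, with a stated time of 48 h, tested at 50 uM; a higher number here means more inhibition of growth at the concentration tested, a lower number less inhibition of growth. Compound 1 gives 62%, and compound 2 gives 60%. Compound 2 stands at the lower of the two numbers, but its nearest neighbour, compound 1, is only a couple of points higher, and that gap lies within the scatter of repeated measurements; the two values are therefore indistinguishable. Compounds 1 and 2 differ in more than one place, so nothing beyond their two values can be read from that pair.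

Compound 3, `O=C1C(=O)N(CCCCn2cc(COc3cc(=O)oc4ccccc34)nn2)c2ccc(Br)cc21`, is not yet measured. It differs from compound 2 in a single place: bromo in place of chloro on an aromatic carbon. Within the data shown here, no step between measured compounds isolates this change. For compound 3 no step beyond the scatter is expected in this assay, in either direction, and the expected step of no change at the digits printed from compound 2 to compound 3 (within the scatter) is essentially flat. The estimate for compound 3 is 60%, with a range from 47% to 73%.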

Compound 3, percent growth inhibition at one concentration: 56%
For compound 3 the middle estimate is 4 percentage points above the measured one, within the range that was stated.
By their numbers in this assay, from the lowest: compounds 3, 2 and 1 (each within the scatter of the next).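

Bromo in place of chloro on an aromatic carbon of the six-membered aromatic ring of carbon only gives, in this assay, a number 4 percentage points lower from compound 2 to compound 3 (within the scatter). Among these compounds, this is the first comparison that isolates a single place, and it shows that at this position the two halogens cannot be told apart in this read-out at the one concentration tested, so the exchange of one for the other has no resolved effect here. Nothing available bears on why the two halogens read alike, and the result is recorded only as an observation.

The compounds shown leave open whether a more different group at this same position, such as an amine, a carboxylic acid or a methoxy group, would produce a step beyond the scatter, or whether this position tolerates such replacements as well. Also open, going by these compounds, is whether chloro and bromo remain indistinguishable at lower concentrations, where a single-concentration read-out of growth inhibition could separate compounds that look alike here.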